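The compounds below may be only part of what the source reports. "The series", "measured", "known", "first", "only" and "open" are said of these compounds alone.

Measured so far in a functional assay (Cavia porcellus) with sulfonylurea receptors; K-ATP channels (Homo sapiens) as the target; on this read-out higher numbers stand for weaker inhibition and lower numbers for stronger inhibition: compound 1 `CC(O)(C(=O)Nc1ccc(S(=O)(=O)c2ccccc2C#N)cc1)C(F)(F)F` gives 1100 nM; compound 2 `CC(O)(C(=O)Nc1ccc(C(=O)c2ccccc2)cc1F)C(F)(F)F` gives 11000 nM; compound 3 `CC(O)(C(=O)Nc1ccc(C(=O)c2ccccc2)cc1O)C(F)(F)F` gives 15000 nM.

Compound 3 stands at the high end of these three numbers. Its nearest neighbour is compound 2, and the step of a 1.4-fold higher number from compound 2 to compound 3 (0.13 log units; within the scatter) lies within the scatter, so the two cannot be told apart on this read-out. Compound 1, built on a different core, gives a number far lower than that of compound 3, beyond the scatter.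

Compound 4 `CC(O)(C(=O)Nc1ccc(C(=O)c2ccccc2)cc1Cl)C(F)(F)F` carries the change (chloro in place of hydroxy on an aromatic carbon), that is, chloro in place of hydroxy on an aromatic carbon. For the measured compounds named here, only one measured step bears on it: the exchange of fluoro for hydroxy at the same carbon, a 1.4-fold higher number from compound 2 to compound 3 (0.13 log units; within the scatter), which stayed within the scatter. Because that step a 1.4-fold higher number from compound 2 to compound 3 (0.13 log units; within the scatter) was small, a further exchange at this carbon is expected to leave this assay essentially unchanged, with no step beyond the scatter. Compound 4 is therefore estimated at 10000 nM, with a range from 4000 nM to 25000 nM. This estimate means a step of a 1.5-fold lower number from compound 3 to compound 4 (0.18 log units; within the scatter).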

Compound 4, half-maximal inhibitory concentration: > 30000 nM
Compound 4: only a limit was reported; the forecaster's own chance of this, stated with the estimate: 5%; middle value at least 3.0-fold (0.47 log units) from the limit.
By their numbers in this assay, from the lowest: compound 1; then compounds 2 and 3 (each within the scatter of the next). At a limit, above all of these: compound 4.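

For the compounds shown here, this carbon does not tolerate every exchange equally: in this assay chloro in place of fluoro gives an at least 2.7-fold higher number from compound 2 to compound 4 (0.43 log units; beyond the scatter) and so moves toward weaker inhibition, the first step at this carbon to clear the scatter. The comparison with hydroxy is less firm: an at least 2.0-fold higher number from compound 3 to compound 4 (0.30 log units; that floor lies within the scatter) is only a floor, and the true step from hydroxy to chloro may or may not exceed the scatter. How far compound 4 lies from the other compounds stays unknown, because its value is a limit and not a number: the limit of > 30000 nM in this assay, at which 1 of the 4 values shown sits.

The compounds shown leave open how an amine or a methoxy group on this carbon would read in this assay and whether any such group would give a number that can be read. They also leave open whether chloro in place of fluoro would produce a comparable step on the core of compound 1.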